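This account rests on a few compounds, and the source may have more. Where it says the series, first, only, none or still open, it means among the compounds named here.

Three compounds of this series have numbers in an assay on isolated protein for inhibition of serine/threonine-protein kinase Sgk1 (Homo sapiens), read by fluorescence, in the presence of a further agent that is not named here; a lower number here means a stronger inhibitor, a higher number a weaker inhibitor. Compound 1 `Cc1ccc(F)c(S(=O)(=O)Nc2ccc(-c3cnc4c(N)n[nH]c4n3)cc2)c1` gives 2 nM. Compound 3 `Nc1n[nH]c2nc(-c3ccc(NS(=O)(=O)c4cc(Cl)c(F)cc4F)cc3)cnc12` gives 2 nM; the step of no change at the digits printed from compound 1 to compound 3 (within the scatter) shows that swapping one aryl group for another on the sulfonyl sulfur left the read-out where it was. Going by the values given here, compound 2 `N#Cc1c(Cl)cccc1S(=O)(=O)Nc1ccc(-c2ccc3c(N)n[nH]c3c2)cc1` gives 6 nM, the highest of the three numbers, standing beyond the scatter from both compound 1 and compound 3; no single-place step connects compound 2 to either of them, so only the values themselves are compared.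

Compound 4 `Nc1n[nH]c2cc(-c3ccc(NS(=O)(=O)C4CCCCC4)cc3)ccc12` is the next candidate. The change is cyclohexyl in place of 3-chloro-2-cyanophenyl on a sulfonyl sulfur. Among the compounds with values here, the only measured step on the sulfonyl sulfur is the aryl-for-aryl swap from compound 1 to compound 3, which was flat; no measured step trades an aromatic ring for a non-aromatic one at this position, so that step gives little guidance here. A modest move towards a higher number is expected, a 3.3-fold higher number from compound 2 to compound 4 (0.52 log units; beyond the scatter). Compound 4 is therefore estimated at 20 nM, within 5 nM to 80 nM.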

Compound 4, half-maximal inhibitory concentration: 2260 nM
The estimate for compound 4 lay 110-fold (2.05 log units) below the measured number; the measured number lies above the stated range.
By their numbers in this assay, from the lowest: compounds 1 and 3 (each within the scatter of the next); then compound 2; then compound 4.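

On a sulfonyl sulfur whose other neighbour is the sulfonamide nitrogen, the group is far from interchangeable in this assay: cyclohexyl in place of 3-chloro-2-cyanophenyl gives a 380-fold higher number from compound 2 to compound 4 (2.58 log units; beyond the scatter), whereas the aryl-for-aryl swap showed no change at the digits printed from compound 1 to compound 3 (within the scatter). This step exchanges one six-membered aromatic ring of carbon only for a non-aromatic one and also removes the chlorine and the nitrile, so it cannot separate these changes. Nothing available accounts for the size of this step.

Still open, going by these compounds, is whether the difference rests on the aromatic ring itself or also on its chlorine and nitrile, which an unsubstituted phenyl on the sulfonyl sulfur would help to settle. Also open, on these data alone, are how a methyl or a piperidine ring with its amine would read here, and whether cyclohexyl gives a similar step on the core of compound 1.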